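Methoxy for Nitro on the Fused Ring: Vero Tolerance

This account rests on a few compounds, and the source may have more. Where it says the series, first, only, none or still open, it means among the compounds named here.

Compound 1, `CNC1=C([N+](=O)[O-])C(c2ccc(N3CCN(c4ccnc5cc(Cl)ccc45)CC3)cc2)c2cc(Cl)ccc2O1`: in an ADME assay on Vero cells (Chlorocebus sabaeus) for cytotoxicity, read by MTT assay, with a stated time of 72 h (a lower number here means that less compound is tolerated, a higher number that more compound is tolerated), compound 1 gives 74500 nM.
Compound 2, `CNC1=C([N+](=O)[O-])C(c2ccc(N3CCN(c4ccnc5cc(Cl)ccc45)CC3)cc2)c2cc([N+](=O)[O-])ccc2O1`: in this assay compound 2 gives 31900 nM.

Among the compounds with values here, compound 2 holds the lowest of the two numbers in this assay; its nearest neighbour is compound 1, and the only measured step is a 2.3-fold lower number from compound 1 to compound 2 (0.37 log units; beyond the scatter), a modest move beyond the scatter. Compound 3, `CNC1=C([N+](=O)[O-])C(c2ccc(N3CCN(c4ccnc5cc(Cl)ccc45)CC3)cc2)c2cc(OC)ccc2O1`, differs from compound 2 by methoxy in place of nitro on an aromatic carbon. Within the data shown here, no measured step exchanges nitro for methoxy, so the bearing of the single known step is indirect: it shows only that changing the group at this carbon shifted the number by a modest amount. Compound 3 is therefore expected to land near the two measured values, with the step of a 1.6-fold higher number from compound 2 to compound 3 (0.20 log units; within the scatter) expected from compound 2. The estimate for compound 3 in this assay is 50000 nM, with a range from 20000 nM to 130000 nM.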

Compound 3, half-maximal cytotoxic concentration: 81900 nM
Compound 3: middle estimate off by 1.6-fold (0.21 log units), on the low side, within the range that was stated.
By their numbers in this assay, from the lowest: compound 2; then compounds 1 and 3 (each within the scatter of the next).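

In this assay, replacing nitro with methoxy on this aromatic carbon, the change from compound 2 to compound 3, gives a 2.6-fold higher number from compound 2 to compound 3 (0.41 log units; beyond the scatter), so the shift seen earlier for the nitro compound now appears against a second group. Methoxy and chloro at this carbon cannot be told apart, with a 1.1-fold higher number from compound 1 to compound 3 (0.04 log units; within the scatter), which leaves compound 2 as the only one of the three set apart from both others, with the lowest number and the least compound tolerated. Nothing available explains why the nitro compound stands apart.

Only three groups at this one carbon are shown, so three points cannot establish a trend across substituents. As far as these compounds go, whether an amine, a carboxylic acid or a longer chain such as ethoxy here would stay with chloro and methoxy or fall with nitro remains open.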